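The source may hold more compounds than are shown below. What is called first, only, known or untested is meant among the compounds shown, and "the series" means these compounds.

In an ADME assay (liver) for metabolic stability, with Liver microsome (Homo sapiens) as the target, read by LC-MS, using microsomes, with a stated time of 30 min, tested at 4 uM (on this read-out lower numbers stand for a less stable compound and higher numbers for a more stable compound), three compounds with a shared core had been measured. Compound 1 (`CCN1CCN(c2nc(C)nc3c2nc(-c2ccccc2Cl)n3CCOC)CC1`) gave 31%, compound 2 (`Cc1nc(N2CCN(C)CC2)c2nc(-c3ccccc3Cl)n(CCN3CCCC3=O)c2n1`) gave 13%, and compound 3 (`Cc1nc(N2CCN(C)CC2)c2nc(-c3cccc(Cl)c3)n(C3CCOCC3)c2n1`) gave 25%. The gap between compound 3 and compound 1 lay within the scatter, so these two could not be told apart. The gap between compound 3 and compound 2 lay beyond the scatter, which placed compound 3 clearly on the more stable side of compound 2.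

The next compound to be tested was compound 4 (`Cc1nc(N2CCN(C)CC2)c2nc(-c3ccccc3F)n(C3CCOCC3)c2n1`). It differed from compound 3 in a single place: 2-fluorophenyl in place of 3-chlorophenyl on an aromatic carbon. In words, 2-fluorophenyl stood in place of 3-chlorophenyl on an aromatic carbon, and the oxan-4-yl group remained. Going by the values given here, no two measured compounds differed in only one place, so the data offered no direct precedent for this change. Among the compounds with values here, the only anchor was compound 3 at 25%, and no shift beyond the scatter was expected in this assay. The expected step, a number 2 percentage points higher from compound 3 to compound 4 (within the scatter), was small and its direction uncertain. Compound 4 was estimated at 27%, with an expected range from 12% to 45%.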

Compound 4, percent of the compound remaining: 10%
The estimate for compound 4 lay 17 percentage points above the measured number, and the stated range ends above it.
By their numbers in this assay, from the lowest: compounds 4 and 2 (each within the scatter of the next); then compounds 3 and 1 (each within the scatter of the next).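

In this assay, going by these compounds alone, the exchange of 3-chlorophenyl for 2-fluorophenyl, on an aromatic carbon next to the ring atom that bears an oxan-4-yl group, gave a number 15 percentage points lower from compound 3 to compound 4 (beyond the scatter), the first comparison in this set between compounds that differ in one place. It shows that the read-out at this position is sensitive to the phenyl group it carries, even though the two groups have the same heavy-atom count and neither has hydrogen-bond donors or acceptors, so those counts do not track the step in this single pair. Nothing available explains why the number moved as it did.

This one step changes both the halogen and its place on the phenyl ring, and the compounds shown do not separate these two changes. Going by these compounds, how 3-fluorophenyl, 2-chlorophenyl or an unsubstituted phenyl would read at this position with the oxan-4-yl group and the rest of the structure kept remains open, as does whether the same step would appear with a different group on the neighbouring ring atom.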